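The source may report more compounds than this note shows. Statements on the series, on what has been measured and on what is new or still open speak of the compounds shown alone.

Series so far, in a functional assay on Bel-7402 cells (Homo sapiens) for antiproliferative activity, read by MTT assay, with a stated time of 72 h; a higher number here means a weaker inhibitor, a lower number a stronger inhibitor:
- compound 1 `C=C1C(=O)O[C@H]2[C@H]1CC/C(COC(=O)Cn1cc(F)c(=O)[nH]c1=O)=C\CC[C@@]1(C)O[C@@H]21`: > 20000 nM (a limit of the assay, not a number)
- compound 2 `C=C1C(=O)O[C@H]2[C@H]1CC/C(COC(=O)Cn1cc(F)c(=O)n(Cc3ccccc3)c1=O)=C\CC[C@@]1(C)O[C@@H]21`: 3980 nM
- compound 3 `C=C1C(=O)O[C@H]2[C@H]1CC/C(COC(=O)Cn1cc(F)c(=O)n(Cc3ccc(F)c(F)c3)c1=O)=C\CC[C@@]1(C)O[C@@H]21`: 2700 nM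

Compound 3 has the lowest of the numeric values, but it is not separated from compound 2, with a 1.5-fold lower number from compound 2 to compound 3 (0.17 log units; within the scatter).

Next is compound 4 `C=C1C(=O)O[C@H]2[C@H]1CC/C(COC(=O)Cn1cc(F)c(=O)n(C)c1=O)=C\CC[C@@]1(C)O[C@@H]21`, with this change: hydrogen in place of 3,4-difluorophenyl on a saturated chain carbon bound to an aromatic nitrogen. In words, hydrogen takes the place of 3,4-difluorophenyl on a saturated chain carbon bound to an aromatic nitrogen, so 3,4-difluorobenzyl becomes methyl.

Among the compounds with values here, two steps bear on this most directly, an at least 5.0-fold lower number from compound 1 to compound 2 (0.70 log units; beyond the scatter) and an at least 7.4-fold lower number from compound 1 to compound 3 (0.86 log units; beyond the scatter). Both start from a limit, so their true sizes are open. The step of a 1.5-fold lower number from compound 2 to compound 3 (0.17 log units; within the scatter) adds that the fluorines on the benzyl group have shown no effect beyond the scatter. Methyl itself is untested, and compound 4 is expected to fall between compound 3 and the limit of compound 1.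

A modest rise in the number is expected, a 3.0-fold higher number from compound 3 to compound 4 (0.47 log units; beyond the scatter). For compound 4 the estimated value is 8000 nM, with an expected range of 3000 nM to 20000 nM.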

Compound 4, half-maximal inhibitory concentration: 9400 nM
The estimate for compound 4 lay 1.2-fold (0.07 log units) below the measured number; low and high end bracket the measured number.
By their numbers in this assay, from the lowest: compounds 3 and 2 (each within the scatter of the next); then compound 4. At a limit, above all of these: compound 1.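

In this assay, replacing the aryl ring of the benzyl groups with hydrogen gives a 3.5-fold higher number from compound 3 to compound 4 (0.54 log units; beyond the scatter) and a 2.4-fold higher number from compound 2 to compound 4 (0.37 log units; beyond the scatter), so at this position the ring contributes beyond the scatter, whether or not it carries the two fluorines. Methyl alone still retains part of the gain over the unsubstituted aromatic nitrogen, with an at least 2.1-fold lower number from compound 1 to compound 4 (0.32 log units; beyond the scatter), so the smallest group shown already separates from hydrogen, though by an open amount. Compound 1 stands at a limit, not a number: the limit of > 20000 nM in this assay, at which 1 of the 4 values shown sits.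

Open, from the compounds shown here alone, is whether an ethyl or propyl group would give numbers nearer those of the benzyl compounds, which would show how much depends on the aryl ring itself. Also open, going by these compounds, is how a pyridylmethyl group, or a chain ending in an amine or a carboxylic acid, would behave on this nitrogen.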